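The source may report more compounds than this note shows. Statements on the series, on what has been measured and on what is new or still open speak of the compounds shown alone.

Measured so far in a functional assay on DU-145 cells (Homo sapiens) for inhibition; on this read-out higher numbers stand for weaker inhibition and lower numbers for stronger inhibition:
Compound 1, `Oc1ccc(-c2cc(-c3ccccc3F)cc(-c3ccc(O)cc3)n2)cc1`, gives 7780 nM.
Compound 2, `Oc1ccccc1-c1cc(-c2ccccc2OC(F)(F)F)cc(-c2ccccc2O)n1`, gives 5850 nM.
Compound 3, `Oc1ccc(-c2cc(-c3ccccc3OC(F)(F)F)cc(-c3ccccc3O)n2)cc1`, gives 4190 nM.

Compound 3 has the lowest number of the three, yet its gaps to compound 2 and to compound 1 both fall within the usual scatter, so no order among the three is established by these data. Compound 4, `Oc1ccc(-c2cc(-c3ccccc3OC(F)(F)F)cc(-c3ccc(O)cc3)n2)cc1`, has not yet been measured in this assay. Compound 4 differs from compound 3 by 4-hydroxyphenyl in place of 2-hydroxyphenyl on an aromatic carbon. One measured step is of the same kind: a 1.4-fold lower number from compound 2 to compound 3 (0.14 log units; within the scatter). That step exchanged a 2-hydroxyphenyl for a 4-hydroxyphenyl at a different place on the shared core and stayed within the scatter. Compound 1, which carries two 4-hydroxyphenyl groups alongside a different third group, gives a number somewhat above that of compound 3, again within the scatter. Nothing in the series therefore points to a step beyond the scatter for this exchange, and the expected step of a 1.2-fold lower number from compound 3 to compound 4 (0.08 log units; within the scatter) is taken to be small, if anything towards a slightly lower number. Compound 4 is estimated at 3500 nM, with a range of 1500 nM to 8500 nM.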

Compound 4, half-maximal inhibitory concentration: 16000 nM
Estimate against measurement, compound 4: 4.6-fold (0.66 log units) below; measured number above the stated range.
By their numbers in this assay, from the lowest: compounds 3, 2 and 1 (each within the scatter of the next); then compound 4.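

In this assay, the exchange at this place, next to the ring nitrogen, gives a step beyond the scatter (a 3.8-fold higher number from compound 3 to compound 4 (0.58 log units; beyond the scatter)), whereas the same kind of exchange from compound 2 to compound 3, which leaves one 2-hydroxyphenyl on the shared core, stays within it (a 1.4-fold lower number from compound 2 to compound 3 (0.14 log units; within the scatter)). Compound 4 carries no 2-hydroxyphenyl, yet that absence alone does not set its number, since compound 1 also lacks that group and the change of the third group, with both 4-hydroxyphenyl groups held constant, is itself a modest step beyond the scatter (a 2.1-fold higher number from compound 1 to compound 4 (0.31 log units; beyond the scatter)). No measurement available here accounts for either step.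

On these data alone, with only these steps, the size of the hydroxyphenyl exchange can be read solely with trifluoromethoxy as the third group, so it remains open whether the same exchange would give a comparable step with fluoro in that place. As far as these compounds go, it is also open whether the hydroxyl of the 2-hydroxyphenyl group is what matters at this place, a question that a 2-methoxyphenyl or 2-aminophenyl group there would address.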